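Lengthening the Side Chain of Compound 1

This account rests on a few compounds, and the source may have more. Where it says the series, first, only, none or still open, it means among the compounds named here.

Compound 1: `COc1c(OCCCN2CCNCC2)cc(O)c2c(=O)cc(-c3ccccc3)oc12` — 10100 nM
Compound 2: `CCN(CC)CCCOc1c(O)cc(O)c2c(=O)cc(-c3ccccc3)oc12` — > 100000 nM
Compound 3: `COc1ccc(-c2cc(=O)c3c(O)cc(O)c(OC)c3o2)cc1` — "not determined" (no result reported)

Within the data shown here, in a functional assay on A549 cells (Homo sapiens) for cytotoxicity, read by MTT assay, with a stated time of 48 h (a higher number here means a weaker inhibitor, a lower number a stronger inhibitor), compound 1 gives 10100 nM, the only firm number among the three measured compounds. Compound 2 reaches only a limit of the assay, > 100000 nM, as noted in the limit of > 100000 nM in this assay, at which 1 of the 3 values shown sits. For compound 3, this assay shows "not determined" (no result reported). Compound 4, `COc1c(OCCCCN2CCN(C)CC2)cc(O)c2c(=O)cc(-c3ccccc3)oc12`, differs from compound 1 by (4-methylpiperazin-1-yl)methyl in place of piperazin-1-yl on a saturated chain carbon, three bonds along the chain from an oxygen on an aromatic ring. Among the measured compounds shown here, no pair of measured compounds differs in a single place, so no measured step guides the expectation; the change is expected to shift the value only within the scatter of this assay, with no clear direction. Compound 4 is therefore estimated at 10000 nM, between 3000 nM and 35000 nM, an expected step of a 1.0-fold lower number from compound 1 to compound 4 (0.00 log units; within the scatter).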

Compound 4, half-maximal inhibitory concentration: 1500 nM
Estimate against measurement, compound 4: 6.7-fold (0.82 log units) above; the measured number lies below the stated range.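

Placing (4-methylpiperazin-1-yl)methyl in place of piperazin-1-yl on this saturated chain carbon gives, in this assay, a 6.7-fold lower number from compound 1 to compound 4 (0.83 log units; beyond the scatter). This only measured step shows that the value responds to a change at this position, and that the response lies beyond the scatter. The change lengthens the chain and puts a methyl on the piperazine together, and no measurement shown bears on the cause of the step.

Which of these two parts carries the step stays open. So does how a morpholine ring or a still longer chain would read here.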